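A few compounds are considered here, and "the series" means these few. Any claim that something is new, unique, unknown or untested is made for them only; others in the source may bear on it.

Compound 1, `COc1ccc(Cl)cc1C(C)NC(=O)NS(=O)(=O)c1ccccc1`, in a functional assay on thoracic aorta (Rattus norvegicus, strain Wistar), with a stated time of 15 min; a lower number here means that less compound is needed, a higher number that more compound is needed for the effect: > 300000 nM, which is a limit of the assay and not a number.
Compound 2, `COc1ccc(Br)cc1C(C)NC(=O)NS(=O)(=O)c1ccccc1`, in this assay: > 300000 nM, also a limit of the assay.
Compound 3, `COc1ccc(Br)cc1C(C)NC(=O)N(C)S(=O)(=O)c1ccc(C)cc1`, in this assay: 19100 nM.

Compound 1 and compound 2 differ in one place: chloro in place of bromo on an aromatic carbon. Their two values in this assay are both limits, so the step that the two limits leave unreadable from compound 2 to compound 1 cannot be read, because the limit of > 300000 nM in this assay, at which 2 of the 3 values shown sit, is where both of them sit. Among the measured compounds shown here, compound 3 carries the only number of the three; how its core differs from the core of compound 2 is not broken down here.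

Compound 4, `COc1ccc(Cl)cc1C(C)NC(=O)N(C)S(=O)(=O)c1ccc(C)cc1`, has not yet been measured in this assay. It differs from compound 3 by chloro in place of bromo on an aromatic carbon, the same change that separates compound 2 from compound 1, at the same place. That earlier step gives no guidance on size, since both of its ends are limits. The expectation for compound 4 therefore rests on compound 3 and its value 19100 nM. A swap of one halogen for another at one aromatic carbon is expected to move the result only a little, so the step of a 1.3-fold higher number from compound 3 to compound 4 (0.12 log units; within the scatter) is estimated to stay within the usual scatter. Compound 4 is therefore expected to give about 25000 nM in this assay, most likely between 8000 nM and 80000 nM.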

Compound 4, half-maximal effective concentration: 13800 nM
For compound 4 the middle estimate is 1.8-fold (0.26 log units) above the measured one; low and high end bracket the measured number.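

In this assay, putting chloro in place of bromo on the aromatic carbon para to the methoxy group gives a 1.4-fold lower number from compound 3 to compound 4 (0.14 log units; within the scatter), so on this core the two halogens cannot be told apart. Compound 1 and compound 2 carry the same change on the other core, but both sit at a limit of the assay, which is not a number, so their step cannot be read: the limit of > 300000 nM in this assay, at which 2 of the 4 values shown sit. Among the compounds shown here, the series therefore shows one readable case of this change, which stays within the scatter, but it does not show that the change carries the same size from one core to the other, as there is no second step to set beside the first.

Still open, on these data alone, is what a different group at this aromatic carbon, such as fluoro, an amine or a carboxylic acid, would do to the number on the core of compound 3. Also open is which of the places where the core of compound 3 differs from the core of compound 2 goes with having a number rather than a limit, as no pair shown separates them.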